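Swapping Methoxy for Fluoro in a Cytotoxicity Series

This account rests on a few compounds, and the source may have more. Where it says the series, first, only, none or still open, it means among the compounds named here.

Compound 1 `COc1ccc(C(=O)N/N=C/C2=Cc3ccccc3OC2)cc1` gives 36000 nM in a toxicity assay on HEK-293T cells (Homo sapiens) for cytotoxicity, read by MTT assay, with a stated time of 72 h; on this read-out higher numbers stand for weaker inhibition and lower numbers for stronger inhibition.
Compound 2 `COc1ccc(C(=O)N/N=C/C2=Cc3ccccc3OC2c2ccccc2)cc1` gives 90700 nM in this assay.

Compound 2 stands highest of the two measured numbers; its nearest neighbour is compound 1, and the step of a 2.5-fold higher number from compound 1 to compound 2 (0.40 log units; beyond the scatter) came from a phenyl in place of hydrogen on a saturated ring carbon. Compound 3 `O=C(N/N=C/C1=Cc2ccccc2OC1c1ccccc1)c1ccc(F)cc1` differs from compound 2 at a different site: fluoro in place of methoxy on an aromatic carbon. No measured step touches this change, so nothing shown predicts a shift beyond the scatter. Compound 3 is expected to give about 85000 nM in this assay, within 35000 nM to 200000 nM. The expected step is a 1.1-fold lower number from compound 2 to compound 3 (0.03 log units; within the scatter).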

Compound 3, half-maximal inhibitory concentration: 30900 nM
Estimate against measurement, compound 3: 2.8-fold (0.44 log units) above; the whole stated range lies above it.
By their numbers in this assay, from the lowest: compounds 3 and 1 (each within the scatter of the next); then compound 2.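

In this assay, replacing 4-methoxyphenyl with 4-fluorophenyl gives a 2.9-fold lower number from compound 2 to compound 3 (0.47 log units; beyond the scatter), so the substituent at this aromatic carbon, para to a large group, can shift the read-out. The earlier step, made on a saturated ring carbon, could not show this. Nothing measured here explains the shift.

Going by these compounds, whether the shift comes from gaining fluoro or from losing methoxy remains open, and a chlorine atom, an amine or a plain hydrogen at this place would help separate the two. Whether the same swap has the same effect on the core of compound 1 is also unknown.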